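From piperidin-1-yl to cyclopentylamino on a sulfonyl sulfur

The source may hold more compounds than are shown below. What is called first, only, known or untested is meant among the compounds shown, and "the series" means these compounds.

Measured in a physicochemical assay for solubility, in phosphate buffer, measured as kinetic solubility, at pH 7.4, tested at 250 uM; a higher number here means a more soluble compound, a lower number a less soluble compound:
compound 1 `O=C(O)c1ccc(NCCCCCCCC(F)(F)F)c(S(=O)(=O)N2CCCC2)c1`: 66000 nM
compound 2 `O=C(O)c1ccc(NCCCCCCCC(F)(F)F)c(S(=O)(=O)N2CCCCC2)c1`: 13000 nM

Compound 2, at 13000 nM, holds the lower of the two numbers. Compound 3 `O=C(O)c1ccc(NCCCCCCCC(F)(F)F)c(S(=O)(=O)NC2CCCC2)c1` carries cyclopentylamino in place of piperidin-1-yl on a sulfonyl sulfur. Among the compounds with values here, one measured step bears on this change, at the same sulfur: a 5.1-fold lower number from compound 1 to compound 2 (0.71 log units; beyond the scatter). Within the data shown here, no measured compound carries cyclopentylamino, so the direction remains uncertain. In this assay a step of that size or smaller is expected, tentatively towards a higher number, and the expected step is a 2.3-fold higher number from compound 2 to compound 3 (0.36 log units; beyond the scatter). Compound 3 is estimated at 30000 nM, with an expected range from 9000 nM to 90000 nM.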

Compound 3, solubility: 223000 nM
Estimate against measurement, compound 3: 7.4-fold (0.87 log units) below; measured number outside the range, above it.
By their numbers in this assay, from the lowest: compound 2; then compound 1; then compound 3.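

In this assay, the change of cyclopentylamino for piperidin-1-yl on the sulfonyl sulfur gives a 17-fold higher number from compound 2 to compound 3 (1.23 log units; beyond the scatter), and the change for pyrrolidin-1-yl gives a 3.4-fold higher number from compound 1 to compound 3 (0.53 log units; beyond the scatter). Within the data shown here, compound 3 therefore stands above both ring-bound amines, so this position tolerates more than a choice between them, and the one group with a hydrogen-bond donor gives the highest number. Nothing shown here accounts for these steps.

As far as these compounds go, whether the rise follows the hydrogen on the nitrogen or the cyclopentyl ring stays open. Cyclopentyl(methyl)amino and cyclohexylamino would separate the two.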